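Cyclohexylcarbamate in place of the cyclopropyl thioimidate

The source may hold more compounds than are shown below. What is called first, only, known or untested is meant among the compounds shown, and "the series" means these compounds.

Compound 1 `CC(C)NC(=O)OC[C@H]1OC(n2cnc3c(NC4CCOC4)ncnc32)[C@H](O)[C@@H]1O` and compound 2 `O[C@@H]1[C@@H](CO/C(S)=N/C2CC2)OC(n2cnc3c(NC4CCOC4)ncnc32)[C@@H]1O` share a core and differ only in the group on the oxygen on the saturated carbon. In an assay on DDT1 cells (Cricetulus griseus) for binding affinity to adenosine receptor A1 (Homo sapiens), read by radioligand binding (a lower number here means a stronger inhibitor, a higher number a weaker inhibitor), compound 1 gives 78 nM, and compound 2 gives 157 nM. The step of a 2.0-fold higher number from compound 1 to compound 2 (0.30 log units; within the scatter) shows that the two numbers lie within the scatter of each other, so compound 2 cannot be set apart from compound 1 on these data. Compound 3 `O=C(NC1CCCCC1)OC[C@H]1OC(n2cnc3c(NC4CCOC4)ncnc32)[C@H](O)[C@@H]1O` differs from compound 2 by a group of 9 heavy atoms (7 carbon, 1 nitrogen, 1 oxygen; one six-membered non-aromatic ring of carbon only) in place of a group of 6 heavy atoms (4 carbon, 1 nitrogen, 1 sulfur; one three-membered non-aromatic ring of carbon only), on an oxygen on a saturated carbon. Going by the values given here, only the step from compound 1 to compound 2 bears on this change, and it was within the scatter. A carbamate returns in compound 3, so the number is expected to move back toward that of compound 1, with the step of a 1.8-fold lower number from compound 2 to compound 3 (0.27 log units; within the scatter) expected to stay within the scatter. Compound 3 is therefore estimated at 85 nM, in the range 30 nM to 250 nM.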

Compound 3, inhibition constant: 584 nM
Compound 3: middle estimate off by 6.9-fold (0.84 log units), on the low side; measured number outside the range, above it.
By their numbers in this assay, from the lowest: compounds 1 and 2 (each within the scatter of the next); then compound 3.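

Keeping the carbamate does not hold the number at this position in this assay: cyclohexyl in place of isopropyl on the amide-type nitrogen gives a 7.5-fold higher number from compound 1 to compound 3 (0.87 log units; beyond the scatter). The group on that nitrogen therefore counts for more here than the first pair suggested, and the exchange of the cyclopropyl thioimidate for cyclohexylcarbamoyl gives a 3.7-fold higher number from compound 2 to compound 3 (0.57 log units; beyond the scatter). Nothing in the data shown accounts for this rise.

With only isopropyl and cyclohexyl shown on the carbamate nitrogen, it remains open whether the number climbs in step with the group on that nitrogen, or whether a phenyl or a straight butyl chain there would land nearer compound 1 or compound 3. From the compounds shown here alone, it is also open how a cyclohexyl group would read on the thioimidate, which would separate the effect of that group from the effect of the linking atoms.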